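A few compounds are considered here, and "the series" means these few. Any claim that something is new, unique, unknown or untested is made for them only; others in the source may bear on it.

Compound 3 `O=C(/C=C/c1cccc(NS(=O)(=O)c2ccccc2Cl)c1)c1nc2ccccc2[nH]1` is the one sulfonamide among the three compounds measured. In a functional assay on 143B cells (Homo sapiens) for antiproliferative activity, read by MTT assay, with a stated time of 48 h (a lower number here means a stronger inhibitor, a higher number a weaker inhibitor), compound 3 gives 4790 nM, the second highest of the three numbers. Its nearest neighbour is compound 1 `COc1cccc(C(=O)Nc2cccc(/C=C/C(=O)c3nc4ccccc4[nH]3)c2)c1`, which gives 4610 nM; the step between them is a 1.0-fold higher number from compound 1 to compound 3 (0.02 log units; within the scatter). The furthest is compound 2 `COc1ccc(C(=O)Nc2cccc(/C=C/C(=O)c3nc4ccccc4[nH]3)c2)cc1`, which gives 6330 nM; here the step is a 1.3-fold lower number from compound 2 to compound 3 (0.12 log units; within the scatter). The two amides themselves sit close together, with a 1.4-fold higher number from compound 1 to compound 2 (0.14 log units; within the scatter). All three numbers lie within the scatter of one another, so no ordering among them can be read.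

Compound 4 `O=C(/C=C/c1cccc(NS(=O)(=O)c2cccc(Cl)c2)c1)c1nc2ccccc2[nH]1` differs from compound 3 in a single place: 3-chlorophenyl in place of 2-chlorophenyl on a sulfonyl sulfur. Going by the values given here, no measured step exchanges one chlorophenyl for another, so none bears on this change directly. Among the compounds with values here, the only measured step that alters the substitution pattern of a pendant phenyl ring is the methoxyphenyl exchange, a 1.4-fold higher number from compound 1 to compound 2 (0.14 log units; within the scatter), which stayed within the scatter; the two exchanges on the ring nitrogen, which swapped a whole carbonyl group for a sulfonyl group, likewise stayed within the scatter. On this basis no step beyond the scatter is expected in this assay, in either direction, and the expected step is a 1.0-fold higher number from compound 3 to compound 4 (0.00 log units; within the scatter). Compound 4 is therefore estimated at 4800 nM, with an expected range from 2400 nM to 9600 nM.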

Compound 4, half-maximal inhibitory concentration: 2510 nM
Beside the measured number, compound 4's estimate is 1.9-fold (0.28 log units) above it; measured number inside the range.
By their numbers in this assay, from the lowest: compounds 4, 1, 3 and 2 (each within the scatter of the next, the first and the last beyond it).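

In this assay, exchanging 2-chlorophenyl for 3-chlorophenyl on a sulfonyl sulfur gives a step that stays inside repeat variation (a 1.9-fold lower number from compound 3 to compound 4 (0.28 log units; within the scatter)), so this change alone does not separate compound 3 from compound 4. Compound 4 does, however, give the first step beyond the scatter among these compounds, though a modest one, when its (3-chlorophenyl)sulfonyl group takes the place of the (4-methoxyphenyl)carbonyl group on the nitrogen on an aromatic ring (a 2.5-fold lower number from compound 2 to compound 4 (0.40 log units; beyond the scatter)); this is no general sulfonamide-over-amide pattern, as the step from the other amide stays within the scatter (a 1.8-fold lower number from compound 1 to compound 4 (0.26 log units; within the scatter)), and compound 3 also goes against it, with neither of its steps to the two amides beyond the scatter. No measurement is available that would account for any of these steps.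

Open, as far as these compounds go, is what an unsubstituted phenyl, a phenyl carrying a carboxylic acid or an amine, or a straight alkyl chain would give in place of the chlorophenyl on a sulfonyl sulfur. Also open, from the compounds shown here alone, is whether the sulfonamide nitrogen tolerates a methyl group in place of its hydrogen in this assay.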